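Swapping bromo for methoxy in compound 3

The compounds below may be only part of what the source reports. "The series", "measured", "known", "first", "only" and "open" are said of these compounds alone.

Measured so far in a functional assay on MDA-MB-231 cells (Homo sapiens) for antiproliferative activity, read by MTT assay, with a stated time of 72 h (on this read-out higher numbers stand for weaker inhibition and lower numbers for stronger inhibition), for three compounds:
Compound 1 `COc1cc(-c2nccn2C)cc(OC)c1OC` gives > 100000 nM (a limit of the assay, not a number)
Compound 2 `CCCCn1ccnc1-c1cc(OC)c(OC)c(OC)c1` gives 70400 nM
Compound 3 `COc1cc(-c2nccn2-c2ccc(Br)cc2)cc(OC)c1OC` gives 8400 nM

The lower of the two true numbers comes with an 8.4-fold lower number from compound 2 to compound 3 (0.92 log units; beyond the scatter). Compound 3 also shows an at least 11-fold lower number from compound 1 to compound 3 (1.07 log units; beyond the scatter) when set against the limit. Compound 4 `COc1ccc(-n2ccnc2-c2cc(OC)c(OC)c(OC)c2)cc1` changes 4-bromophenyl to 4-methoxyphenyl (methoxy in place of bromo on an aromatic carbon). Among the measured compounds shown here, no measured step swaps bromo for another group. The two steps above replace the whole 4-bromophenyl, whereas compound 4 changes only the group on it, so neither sets the size of this step. In this assay, no step beyond the scatter is therefore expected, and the estimated change is a 1.3-fold higher number from compound 3 to compound 4 (0.12 log units; within the scatter). For compound 4 the expected value is 11000 nM, within an estimated range of 3000 nM to 40000 nM.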

Compound 4, half-maximal inhibitory concentration: 2700 nM
Compound 4: the middle estimate sits 4.1-fold (0.61 log units) above what was measured; the whole stated range lies above it.
By their numbers in this assay, from the lowest: compound 4; then compound 3; then compound 2. At a limit, above all of these: compound 1.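

Changing only the group on the 4-substituted phenyl ring, with the ring itself kept, shifts the result in this assay: a 3.1-fold lower number from compound 3 to compound 4 (0.49 log units; beyond the scatter). This single swap of bromo for methoxy adds to the gain over the butyl chain, giving a 26-fold lower number from compound 2 to compound 4 (1.42 log units; beyond the scatter). The comparison with the methyl on the aromatic nitrogen gives only a floor, an at least 37-fold lower number from compound 1 to compound 4 (1.56 log units; beyond the scatter), and it rests on a limit, not a number: the limit of > 100000 nM in this assay, at which 1 of the 4 values shown sits.

Only two groups at this place are shown. An amine, a carboxylic acid or a longer chain there could land anywhere on this scale.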